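Fluoro in place of methyl: compound 3 in outlook

A few compounds are considered here, and "the series" means these few. Any claim that something is new, unique, unknown or untested is made for them only; others in the source may bear on it.

compound 1 `CCNc1cc(-c2ccc(NC(=O)Nc3cccc(Cl)c3)cc2C)ccn1`: 4180 nM
compound 2 `CCNc1cc(-c2ccc(NC(=O)Nc3cccc4ccccc34)cc2C)ccn1`: 15500 nM

In a functional assay on MCF7 cells (Homo sapiens) for cytotoxicity, read by MTT assay, with a stated time of 24 h (a lower number here means a stronger inhibitor, a higher number a weaker inhibitor), compound 1 holds the lower of the two numbers. Compound 3 `CCNc1cc(-c2ccc(NC(=O)Nc3cccc(Cl)c3)cc2F)ccn1` differs from it by fluoro in place of methyl on an aromatic carbon, ortho to a 2-(ethylamino)pyridin-4-yl group. Going by the values given here, the only measured step, a 3.7-fold higher number from compound 1 to compound 2 (0.57 log units; beyond the scatter), is modest and lies elsewhere, at the amide-type nitrogen, so it gives only a rough scale. Among the compounds with values here, no measured step covers this change. Little or no shift beyond the scatter is therefore expected in this assay, in no firm direction. The expected step is a 1.0-fold lower number from compound 1 to compound 3 (0.02 log units; within the scatter). For compound 3 the estimate is 4000 nM, with an expected range of 1800 nM to 9500 nM.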

Compound 3, half-maximal inhibitory concentration: 6940 nM
Beside the measured number, compound 3's estimate is 1.7-fold (0.24 log units) below it; measured number inside the range.
By their numbers in this assay, from the lowest: compounds 1 and 3 (each within the scatter of the next); then compound 2.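

In this assay, going by these compounds alone, a 1.7-fold higher number from compound 1 to compound 3 (0.22 log units; within the scatter) gives the first measured reading at the position ortho to a 2-(ethylamino)pyridin-4-yl group. Fluoro in place of methyl therefore leaves compound 3 and compound 1 unordered, and methyl is not shown to be needed there. Nothing measured bears on the reason for this result. From the compounds shown here alone, whether a methoxy or an amino group at this position would move the number beyond the scatter remains open. So does whether fluoro gives the same result alongside the naphthalen-1-yl group of compound 2.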